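Swapping piperidine for morpholine on a chromone dithiocarbamate

This account rests on a few compounds, and the source may have more. Where it says the series, first, only, none or still open, it means among the compounds named here.

The compounds here share a chromone-type core carrying a dithiocarbamate side chain, and they were tested in a functional assay on SW480 cells (Homo sapiens) for antiproliferative activity, read by MTT assay, with a stated time of 72 h; on this read-out lower numbers stand for stronger inhibition and higher numbers for weaker inhibition. Compound 2, `O=c1cc(CSC(=S)N2CCCCC2)oc2cc(Cl)ccc12`, carries a piperidin-1-yl group on the thiocarbonyl carbon and gives 2500 nM in this assay, the lowest of the two numbers recorded. Its nearest neighbour is compound 3, `O=c1c(CSC(=S)N2CCOCC2)coc2cc(Cl)ccc12`, which carries a morpholin-4-yl group on a differently substituted version of the core and gives 6200 nM; that gap lies beyond the usual scatter of this assay. Compound 1, `Cc1ccc2c(=O)c(CSC(=S)N(C(C)C)C(C)C)coc2c1`, with a diisopropyl dithiocarbamate and a methyl group on the core, gives > 25000 nM, which is a limit of the assay rather than a number, namely (the limit of > 25000 nM in this assay, at which 1 of the 3 values shown sits), so no number is available for it.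

Compound 4, `O=c1cc(CSC(=S)N2CCOCC2)oc2cc(Cl)ccc12`, is not yet measured. It differs from compound 2 in one place: morpholin-4-yl in place of piperidin-1-yl on a thiocarbonyl carbon. Since compound 3, which also carries morpholin-4-yl, gives a weaker value than compound 2, a modest weakening is expected, though it may stay within the scatter. Compound 4 is therefore estimated at 5000 nM, with a range from 2000 nM to 15000 nM. The expected step of a 2.0-fold higher number from compound 2 to compound 4 (0.30 log units; within the scatter) is small and toward weaker inhibition.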

Compound 4, half-maximal inhibitory concentration: > 25000 nM
Compound 4 was reported as a limit; the forecaster's own chance of this, stated with the estimate: 10%; middle value at least 5.0-fold (0.69 log units) away from the limit.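

In this assay, the change from piperidin-1-yl to morpholin-4-yl on a thiocarbonyl carbon can now be read in one place on an otherwise unchanged compound, and it gives an at least 10-fold higher number from compound 2 to compound 4 (1.00 log units; beyond the scatter), far more than a small shift toward weaker inhibition. The two groups are six-membered non-aromatic rings with the same number of heavy atoms, and they differ in that the morpholin-4-yl ring holds an oxygen where the piperidin-1-yl ring holds a carbon and so counts one hydrogen-bond acceptor more, which shows that this position does not tolerate every ring of this size. Compound 4 is reported as a limit of the assay, not a number, so the true size of the step stays unknown, and compound 4 now shares that limit with compound 1: the limit of > 25000 nM in this assay, at which 2 of the 4 values shown sit.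

Nothing shown says why this single ring atom matters so much, or whether the oxygen itself is what counts. Going by these compounds, whether a piperazin-1-yl ring, with a second nitrogen, or the smaller pyrrolidin-1-yl ring would keep the activity of compound 2 also remains open.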